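Lengthening the Sulfonyl Arm: From Compound 3 to Compound 4

This account rests on a few compounds, and the source may have more. Where it says the series, first, only, none or still open, it means among the compounds named here.

Measured compounds:
compound 1, `O=C(CCCC1CCN(C(=O)c2ccccc2)CC1)c1ncco1` — 77 nM
compound 2, `O=C(CCCC1CCN(C(=O)CCc2ccccc2)CC1)c1ncco1` — 22 nM
compound 3, `O=C(CCCC1CCN(S(=O)(=O)Cc2ccccc2)CC1)c1ncco1` — 600 nM

In an assay on isolated protein for inhibition of Fatty-acid amide hydrolase 1 (Homo sapiens) (on this read-out higher numbers stand for weaker inhibition and lower numbers for stronger inhibition), compound 3 gives 600 nM, the highest number among the three measured compounds and so the weakest inhibitor of the set. Compound 1 gives 77 nM and compound 2 gives 22 nM, both beyond the scatter away from compound 3. All three share the same core; compound 3 alone carries a sulfonyl instead of a carbonyl on the piperidine nitrogen.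

Compound 4, `O=C(CCCC1CCN(S(=O)(=O)CCc2ccccc2)CC1)c1ncco1`, differs from compound 3 in one place: benzyl in place of phenyl on a saturated chain carbon bound to a sulfonyl sulfur. In effect the arm between the sulfonyl and the aromatic ring grows by one chain carbon.

Within the data shown here, one measured step bears on this. Going from compound 1 to compound 2, phenethyl in place of phenyl on a carbonyl carbon gave a 3.5-fold lower number from compound 1 to compound 2 (0.54 log units; beyond the scatter), a modest improvement. Whether a sulfonyl carries the same change in the same way has not been measured, so the step is expected to be in the same direction but uncertain in size, likely again modest, a 2.7-fold lower number from compound 3 to compound 4 (0.44 log units; beyond the scatter).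

Compound 4 is therefore estimated at 220 nM in this assay, expected to fall between 90 nM and 550 nM.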

Compound 4, half-maximal inhibitory concentration: 6 nM
Compound 4: middle estimate off by 37-fold (1.56 log units), on the high side; the measured number lies below the stated range.
By their numbers in this assay, from the lowest: compound 4; then compound 2; then compound 1; then compound 3.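

In this assay, extending the arm on the sulfonyl sulfur by a single chain carbon, benzyl to phenethyl, gives a 100-fold lower number from compound 3 to compound 4 (2.00 log units; beyond the scatter), a large step from a small change, so activity at this position depends strongly on the length of the arm. The comparable carbonyl pair, where phenethyl replaces phenyl, moved only modestly, with a 3.5-fold lower number from compound 1 to compound 2 (0.54 log units; beyond the scatter), and the sulfonyl itself is clearly no bar to a low number: compound 3 has the highest number of the four, yet compound 4, which also carries a sulfonyl, has the lowest, at 6 nM. Nothing available explains why one added chain carbon matters so much on the sulfonyl arm.

Still open, as far as these compounds go, is whether a longer chain, such as phenylpropyl, on the sulfonyl sulfur would lower the number further or reverse the gain, and whether a carboxylic acid or an amine on the phenyl ring would be accepted. Also open, from the compounds shown here alone, is whether so large a step would appear with a different shared core, since all four compounds have the same one.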